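Cytotoxicity notes on an aryl-imidazole amide series

The compounds below may be only part of what the source reports. "The series", "measured", "known", "first", "only" and "open" are said of these compounds alone.

compound 1 `Cn1c(-c2cccc(Cl)c2)cnc1NC(=O)c1ccc(F)cc1` — in a toxicity assay on THP-1 cells (Homo sapiens) for inhibition (a lower number here means that less compound is tolerated, a higher number that more compound is tolerated), compound 1 gives > 50000 nM
compound 2 `Cc1ccccc1-c1cnc(NC(=O)c2ccc(F)cc2)n1C` — in this assay compound 2 gives > 50000 nM
compound 3 `COc1ccc(-c2cnc(NC(=O)c3ccc(F)cc3)n2C)cc1` — in this assay compound 3 gives >= 50000 nM

Each of these values is a limit of the assay, not a number. Compound 3 stands at the limit (the limit of >= 50000 nM in this assay, at which 1 of the 3 values shown sits). Compounds 1 and 2 stand at the limit (the limit of > 50000 nM in this assay, at which 2 of the 3 values shown sit). Among the measured compounds shown here, the series so far gives only limits, so nothing separates the three compounds, and the steps a step that the two limits leave unreadable from compound 1 to compound 2, a step that the two limits leave unreadable from compound 1 to compound 3 and a step that the two limits leave unreadable from compound 2 to compound 3 cannot be read in size or direction.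

Compound 4 `COc1ccc(-c2cnc(NC(=O)c3ccncc3)n2C)cc1` differs from compound 3 in one place: pyridin-4-yl in place of 4-fluorophenyl on a carbonyl carbon. All three measured steps alter the aryl group on the core and leave the amide side untouched, so none of them bears on this change. No direction can be read from the measured compounds. With every measured value sitting at a limit, compound 4 is expected to stay at a limit as well. The expected step of a number no higher from compound 3 to compound 4 (the limit leaves the size open) is therefore none beyond the scatter. Compound 4 is estimated at 50000 nM, with a range from 25000 nM to 100000 nM.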

Compound 4, half-maximal cytotoxic concentration: > 100000 nM
Compound 4 ended at the assay's limit (the forecaster's own chance of this, stated with the estimate: 80%); middle value at least 2.0-fold (0.30 log units) away from the limit.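

In this assay compound 4 gives > 100000 nM, a limit of the assay and not a number. Compound 3 also stands at a limit, and the comparison of compound 3 with compound 4 yields no readable step. The compounds shown leave open what concentration any of the four compounds fails to be tolerated, and whether pyridin-4-yl in place of 4-fluorophenyl alters it.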